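Acetamido in place of nitro on a shared core

The source may report more compounds than this note shows. Statements on the series, on what has been measured and on what is new or still open speak of the compounds shown alone.

Compound 1 `Cc1cccc(C(=O)N2CCCC(C(=O)Nc3ccc(Cl)cc3)C2)c1` and compound 2 `O=C(Nc1ccc(Cl)cc1)C1CCCN(C(=O)c2cccc([N+](=O)[O-])c2)C1` share one core and differ only at a single aromatic carbon. In an ADME assay on PC-3 cells (Homo sapiens) for cytotoxicity, read by WST assay, tested at 100 uM (on this read-out lower numbers stand for less inhibition and higher numbers for more inhibition at the one concentration tested (going by the name of the read-out)), compound 1 gives 0%, and in this assay compound 2 gives 0%. Among the measured compounds shown here, the one measured step, no change at the digits printed from compound 1 to compound 2 (within the scatter), shows that exchanging the group at this carbon left the read-out untouched, so compound 2 stands level with compound 1 and at the bottom of the scale.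

Compound 3 `CC(=O)Nc1cccc(C(=O)N2CCCC(C(=O)Nc3ccc(Cl)cc3)C2)c1` is the next compound in this series; its change from compound 2 is acetamido in place of nitro on an aromatic carbon. For the measured compounds named here, the only step that bears on it is no change at the digits printed from compound 1 to compound 2 (within the scatter), which was no change at this very carbon, and nothing measured suggests that the new group should behave otherwise. Compound 3 is therefore expected to show no change at the digits printed from compound 2 to compound 3 (within the scatter) in this assay, nothing beyond the scatter. The estimate for compound 3 is 0%, with a range from -5% to 12%.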

Compound 3, a percentage reported as inhibition, at one concentration (the size of the read-out at that concentration, not a potency): 4%
The estimate for compound 3 lay 4 percentage points below the measured number, within the range that was stated.
By their numbers in this assay, from the lowest: compounds 1, 2 and 3 (each within the scatter of the next).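

Set against nitro, acetamido at this aromatic carbon gives a number 4 percentage points higher from compound 2 to compound 3 (within the scatter), and set against methyl it gives a number 4 percentage points higher from compound 1 to compound 3 (within the scatter). The position has now carried three groups without a step beyond the scatter in this assay, and this holds for acetamido, which has 1 hydrogen-bond donor where nitro has 0. No measurement at hand speaks to why the read-out stays so low across these compounds.

From the compounds shown here alone, whether an amine, a carboxylic acid or a longer acyl chain on this aromatic carbon would also stay within the scatter remains open. Going by these compounds, it is equally open whether a change elsewhere on the shared core, rather than at this carbon, would move the read-out beyond the scatter.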